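The source may hold more compounds than are shown below. What is called first, only, known or untested is meant among the compounds shown, and "the series" means these compounds.

Three members of one family of adenosine receptor A3 ligands have been measured so far. Compound 1 `Nc1nc(-c2cccs2)nc2cn(-c3ccccc3)nc12` carries an unsubstituted phenyl on its pyrazole nitrogen; compound 2 `COc1ccc(-n2cc3nc(-c4cccs4)nc(N)c3n2)cc1` differs from it only in a methoxy group on that phenyl. Compound 3 `COc1ccc(C(=O)Nc2nc(-c3ccc(OC)cc3)nc3cn(-c4ccccc4)nc23)cc1` is a larger relative in which the free amine of the shared core has become an amide and the thiophene has been replaced. How the core of compound 3 differs from that of compound 2 is not broken down here.

In an assay on CHO cells for displacement of a labelled ligand from adenosine receptor A3 (Homo sapiens), read by scintillation counting, with a stated time of 60 min (a lower number here means a stronger inhibitor, a higher number a weaker inhibitor), compound 1 gives 9.7 nM, compound 2 gives 78 nM, and compound 3 gives 1.31 nM, the lowest of the three. The change from compound 2 to compound 1 hydrogen in place of methoxy on an aromatic carbon gave an 8.0-fold lower number from compound 2 to compound 1 (0.91 log units; beyond the scatter).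

Compound 4 `COc1ccc(-c2nc(NC(=O)c3ccccc3)c3nn(-c4ccccc4)cc3n2)cc1` has not yet been measured. It differs from compound 3 by the same change (hydrogen in place of methoxy on an aromatic carbon), made at the same kind of place but on the benzamido arm rather than on the phenyl attached to the pyrazole. Because the earlier change gave an 8.0-fold lower number from compound 2 to compound 1 (0.91 log units; beyond the scatter), a step in the same direction is expected, though the different surroundings leave the size uncertain, and the expected step is a 1.6-fold lower number from compound 3 to compound 4 (0.21 log units; within the scatter). Compound 4 is therefore estimated at 0.8 nM, with a likely range from 0.2 nM to 3 nM.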

Compound 4, inhibition constant: 6.42 nM
Estimate against measurement, compound 4: 8.0-fold (0.90 log units) below, outside the stated range (above it).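

In this assay, replacing the methoxy on the benzamido arm with hydrogen gave a 4.9-fold higher number from compound 3 to compound 4 (0.69 log units; beyond the scatter), so here the change goes with weaker binding, whereas on the core of compound 1 it went with stronger binding. A swap of methoxy for hydrogen therefore cannot be assumed to act the same way on different cores in this series, since the two steps run in opposite directions and the gap between them is larger than repeat measurements would explain: the same change on two cores in this assay, an 8.0-fold lower number (0.91 log units; beyond the scatter) from compound 2 to compound 1 and a 4.9-fold higher number (0.69 log units; beyond the scatter) from compound 3 to compound 4, 39-fold (1.60 log units) apart, beyond the scatter of two such steps. What these two pairs do not show is which difference between them lies behind the reversal: the amide in place of the free amine, the 4-methoxyphenyl in place of the thiophene, or the methoxy sitting on a different arm.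

The compounds shown leave open whether another group at the same place on the benzamido arm, such as a chlorine atom, a hydroxyl or an ethoxy, would behave as methoxy does. They also leave open what the same swap would do on the 4-methoxyphenyl that compound 4 still carries, and so whether the result belongs to the amide-bearing core or only to this one arm.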